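A few compounds are considered here, and "the series" means these few. Any claim that something is new, unique, unknown or untested is made for them only; others in the source may bear on it.

Compound 1, `CC(=O)/C(=N\Nc1ccccc1)Oc1cccc(Cl)c1`, compound 2, `CC(=O)/C(=N\Nc1ccccc1C(F)(F)F)Oc1cccc(Cl)c1`, and compound 3, `CC(=O)/C(=N\c1ccc(Cl)cc1)NNc1ccccc1C(F)(F)F`, have all been measured in an assay on isolated protein for binding affinity to corticotropin-releasing factor receptor 1 (Homo sapiens); a higher number here means a weaker inhibitor, a lower number a stronger inhibitor. In this assay compound 1 gives > 10000 nM, which is a limit of the assay and not a number. Compound 2 gives > 10000 nM in this assay, again only a limit. Compound 3 gives > 10000 nM in this assay, also a limit. All three therefore sit at the limit of > 10000 nM in this assay, at which 3 of the 3 values shown sit. The change from compound 2 to compound 1 is hydrogen in place of trifluoromethyl on an aromatic carbon; the step it made, a step that the two limits leave unreadable from compound 2 to compound 1, has no readable size because both of its ends rest at the limit of > 10000 nM in this assay, at which 3 of the 3 values shown sit. The difference between the core of compound 3 and the core of compound 2 is not broken down here.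

Compound 4, `CC(=O)/C(=N\c1ccc(Cl)cc1)NNc1ccccc1`, has not yet been measured in this assay. Within the data shown here, it differs from compound 3 by hydrogen in place of trifluoromethyl on an aromatic carbon, which is the same change as the one made from compound 2 to compound 1, at the same kind of place. Resting on a step that the two limits leave unreadable from compound 2 to compound 1 being unreadable and on compound 3 standing at the limit of > 10000 nM in this assay, at which 3 of the 3 values shown sit, compound 4 is expected to give 20000 nM in this assay, most likely again reported only as a limit, with an expected range of 8000 nM to 100000 nM. The step this estimate means, a step that the limit leaves unreadable from compound 3 to compound 4, is expected to be within the usual scatter.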

Compound 4, inhibition constant: > 10000 nM
Compound 4 ended at the assay's limit (the forecaster's own chance of this, stated with the estimate: 90%); the middle value is on the limit's open side.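

Compound 4 gives > 10000 nM in this assay, which is a limit of the assay and not a number. No size can be read for the change from compound 3 to compound 4, because both of its ends rest on a limit: the limit of > 10000 nM in this assay, at which 4 of the 4 values shown sit. The compounds shown leave open whether hydrogen in place of trifluoromethyl changes the binding at all, and which change to these structures would give a readable value.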